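The source may report more compounds than this note shows. Statements on the series, on what has been measured and on what is new or still open speak of the compounds shown alone.

Series notes. The shared core of compound 1 `COc1cc(Nc2ncc(C(F)(F)F)c(N3Cc4cccc(N(C)S(C)(=O)=O)c4C3)n2)cc(OC)c1` is kept through this set while the group on the amine nitrogen is varied. In a functional assay on OVCAR-3 cells (Homo sapiens) for antiproliferative activity, read by spectrophotometry, with a stated time of 2 days (a lower number here means a stronger inhibitor of growth, a higher number a weaker inhibitor of growth), compound 1 gives 630 nM, the lowest of the two numbers at hand. Compound 2 `CN(c1cccc2c1CN(c1nc(Nc3cccc(Oc4ccccc4)c3)ncc1C(F)(F)F)C2)S(C)(=O)=O` in this assay gives 24900 nM, a weaker inhibitor than compound 1 by a margin beyond the scatter. Compound 3 `CN(c1cccc2c1CN(c1nc(Nc3ccc(Nc4ccccc4)cc3)ncc1C(F)(F)F)C2)S(C)(=O)=O` in this assay reaches only a limit of the assay, > 50000 nM; this is the limit of > 50000 nM in this assay, at which 1 of the 3 values shown sits. For the measured compounds named here, compounds 2 and 3 each differ from compound 1 in more than one place, so no single step between measured compounds is available.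

Compound 4 `Cc1ccc(Nc2ncc(C(F)(F)F)c(N3Cc4cccc(N(C)S(C)(=O)=O)c4C3)n2)c(C)c1` is not yet measured in this assay. It differs from compound 1 in one place: 2,4-dimethylphenyl in place of 3,5-dimethoxyphenyl on a nitrogen on an aromatic ring. Going by the values given here, no measured pair isolates this change. The one measured departure from the 3,5-dimethoxyphenyl group of compound 1 that returns a number, compound 2 at 24900 nM, reads weaker. On that basis compound 4 is expected to be a weaker inhibitor than compound 1, with the step of a 4.0-fold higher number from compound 1 to compound 4 (0.60 log units; beyond the scatter) estimated as moderate and beyond the scatter. Compound 4 is estimated at 2500 nM, with a range of 600 nM to 10000 nM.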

Compound 4, concentration for 50% growth inhibition: > 30000 nM
Compound 4 gave a limit, no number; the forecaster's own chance of this, stated with the estimate: 10%; middle value at least 12-fold (1.07 log units) away from the limit.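

For the compounds shown here, at this position on the amine nitrogen, the first single-place step, in this assay, is large and beyond the scatter: an at least 47-fold higher number from compound 1 to compound 4 (1.67 log units; beyond the scatter). Compound 4 gives a limit of the assay and not a number: the limit of > 30000 nM in this assay, at which 1 of the 4 values shown sits. The aromatic ring stays in place across this step, so keeping a six-membered carbon ring on this nitrogen does not by itself preserve the activity of compound 1, and the groups on that ring matter here.

As far as these compounds go, this step changes both the kind of ring substituent and its placement, so the two cannot be told apart, and the size of the loss stays open beyond its limit. A 3,5-dimethylphenyl or a 2,4-dimethoxyphenyl group on the same nitrogen would separate the two contributions.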